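The compounds below may be only part of what the source reports. "The series", "measured", "known", "first", "only" and "open" are said of these compounds alone.

The measured compounds in an assay on HEK293 cells for inhibition of potassium channel subfamily K member 10 (Rattus norvegicus), read by patch clamp; a higher number here means a weaker inhibitor, a lower number a stronger inhibitor:

Compound 1 `Cc1ccc(S(=O)(=O)Nc2ccc(C(=O)/C=C/c3ccc(O)cc3)cc2)cc1` gives 62000 nM.
Compound 2 `COc1ccc(/C=C/C(=O)c2ccc(NS(=O)(=O)c3ccc(C)cc3)cc2)cc1` gives 100000 nM.

Both of these share one core, and both are weak inhibitors. For the measured compounds named here, compound 2 carries the highest of the two numbers, yet its only neighbour, compound 1, sits close by: the step of a 1.6-fold higher number from compound 1 to compound 2 (0.21 log units; within the scatter) comes from putting a methyl in place of hydrogen on the oxygen of the phenol, and it is too small to count as a real change.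

Compound 3 `Cc1ccc(S(=O)(=O)Nc2ccc(C(=O)/C=C/c3ccccc3)cc2)cc1` is the next one to be measured. It differs from compound 2 in one place: hydrogen in place of methoxy on an aromatic carbon. So the whole methoxy group disappears, and a bare phenyl ring remains at the end of the enone.

Going by the values given here, only one measured step bears on this position, and it tells that swapping the hydrogen of the hydroxyl for a methyl left the number where it was, within the scatter. Among the compounds with values here, there is no measured pair in which the oxygen itself is removed. On that thin basis the expectation for compound 3 in this assay is a step of a 1.1-fold lower number from compound 2 to compound 3 (0.05 log units; within the scatter) that stays within the scatter, with no clear direction. Compound 3 is therefore estimated at 90000 nM, with a likely range from 35000 nM to 250000 nM.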

Compound 3, half-maximal inhibitory concentration: > 100000 nM
Compound 3 ended at the assay's limit (the forecaster's own chance of this, stated with the estimate: 35%); at least 1.1-fold (0.04 log units) between middle value and limit.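

In this assay compound 3 gives > 100000 nM, which is a limit of the assay and not a number. The earlier pair changed only what sat on the oxygen, whereas here the oxygen itself goes, and replacing hydroxy with hydrogen gives an at least 1.6-fold higher number from compound 1 to compound 3 (0.20 log units; that floor lies within the scatter), so this pair shows no gain in inhibition but cannot establish a real loss. Replacing methoxy with hydrogen gives a number no lower from compound 2 to compound 3 (the limit leaves the size open), and the position therefore shows the same picture for all three groups: hydroxy, methoxy and bare hydrogen all leave the compound a weak inhibitor, with no sign that removing the oxygen helps, and the true size of the change is hidden at the top of the range: the limit of > 100000 nM in this assay, at which 1 of the 3 values shown sits.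

As far as these compounds go, whether the bare phenyl ring is truly weaker than the 4-methoxyphenyl or hydroxy-bearing ring stays open. Also open, from the compounds shown here alone, is what an amine or a carboxylic acid on this aromatic carbon, or a longer chain on the oxygen, would do to the number.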